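Testing a Fourth Aromatic Ring Variant on the Same Scaffold

The source may hold more compounds than are shown below. What is called first, only, known or untested is meant among the compounds shown, and "the series" means these compounds.

Compound 1 `CCC(C)(C)Cc1c[nH]c(CCc2ccc(-c3ccncc3)cc2)n1` gives 95 nM in a functional assay on HEK293 cells for agonist activity at Bombesin receptor subtype-3 (Homo sapiens), read by luminescence and calcium flux, with a stated time of 10 min; on this read-out lower numbers stand for an effect already at smaller amounts and higher numbers for an effect only at larger amounts of compound.
Compound 2 `CCC(C)(C)Cc1c[nH]c(CCc2ccc(-c3csnn3)cc2)n1` gives 104 nM in this assay.
Compound 3 `CCC(C)(C)Cc1c[nH]c(CCc2ccc(-c3cnccn3)cc2)n1` gives 100 nM in this assay.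

These three values sit within the usual scatter of one another, so compound 2 is not set apart from compound 1 or compound 3. Compound 4 `CCC(C)(C)Cc1c[nH]c(CCc2ccc(-c3cccc(C)n3)cc2)n1` has not been measured. It differs from compound 2 in one place: 6-methylpyridin-2-yl in place of 1,2,3-thiadiazol-4-yl on an aromatic carbon. Among the compounds with values here, the steps that bear on this are a 1.0-fold lower number from compound 2 to compound 3 (0.02 log units; within the scatter) and a 1.1-fold higher number from compound 1 to compound 2 (0.04 log units; within the scatter), both exchanges of the aromatic ring at the same position and both within the scatter. A similar outcome is therefore expected for compound 4, with a step of a 1.1-fold higher number from compound 2 to compound 4 (0.02 log units; within the scatter) in this assay that is not beyond the scatter. Compound 4 is estimated at 110 nM, in the range 45 nM to 270 nM.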

Compound 4, half-maximal effective concentration: 102 nM
Compound 4: the middle estimate sits 1.1-fold (0.03 log units) above what was measured; low and high end bracket the measured number.
By their numbers in this assay, from the lowest: compounds 1, 3, 4 and 2 (each within the scatter of the next).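

The methyl-bearing 6-methylpyridin-2-yl ring fits this position, para to a large group, as well as the unsubstituted rings do: in this assay there is a 1.0-fold lower number from compound 2 to compound 4 (0.01 log units; within the scatter), a 1.0-fold higher number from compound 3 to compound 4 (0.01 log units; within the scatter) and a 1.1-fold higher number from compound 1 to compound 4 (0.03 log units; within the scatter). Across these four compounds, a group with more heavy atoms and fewer hydrogen-bond acceptors than 1,2,3-thiadiazol-4-yl leaves the number within the scatter. No measurement here explains why these exchanges make so little difference. As far as these compounds go, all four compounds carry an aromatic ring at this position, so the effect of an amine, a carboxylic acid or a longer carbon chain there remains open.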